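Trading a Benzyl Group for an Ester on Two Cores

The source may report more compounds than this note shows. Statements on the series, on what has been measured and on what is new or still open speak of the compounds shown alone.

Four compounds share a fused bicyclic ketone core and a triazole ring, but differ in how the triazole is tethered and in what hangs from it. Compound 1 `O=C1C[C@H](OCc2cn(Cc3ccccc3)nn2)[C@H]2CO[C@@H]1O2` joins the triazole through an ether and carries a benzyl group. In a functional assay on MDA-MB-231 cells (Homo sapiens) for cytotoxicity, read by MTT assay, with a stated time of 48 h (on this read-out higher numbers stand for weaker inhibition and lower numbers for stronger inhibition), compound 1 gives > 50000 nM, which is a limit of the assay rather than a number. Compound 2 `COC(=O)Cn1cc(CO[C@H]2CC(=O)[C@@H]3OC[C@H]2O3)nn1` differs from compound 1 in one place: methoxycarbonyl in place of phenyl on a saturated chain carbon bound to an aromatic nitrogen. In this assay compound 2 gives 21300 nM. The change made an at least 2.3-fold lower number from compound 1 to compound 2 (0.37 log units; beyond the scatter), and the step can be read only as a bound because of the limit of > 50000 nM in this assay, at which 2 of the 3 values shown sit.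

Compound 3 `CC(=O)N(Cc1cn(Cc2ccccc2)nn1)[C@H]1CC(=O)[C@@H]2OC[C@H]1O2` attaches the triazole through an acetylated nitrogen instead; the difference between its core and that of compound 1 is not broken down here. In this assay compound 3 gives > 50000 nM, again a limit rather than a number. Compound 4 `COC(=O)Cn1cc(CN(C(C)=O)[C@H]2CC(=O)[C@@H]3OC[C@H]2O3)nn1` has not yet been measured and stands to compound 3 as compound 2 stands to compound 1: methoxycarbonyl in place of phenyl on a saturated chain carbon bound to an aromatic nitrogen. The place is the same in both pairs, so this is the same change. The expected step is an at least 1.6-fold lower number from compound 3 to compound 4 (0.22 log units; that floor lies within the scatter), resting on an at least 2.3-fold lower number from compound 1 to compound 2 (0.37 log units; beyond the scatter) as the only measured case of this change. For compound 4 the expected value is 30000 nM, with a range from 12000 nM to 80000 nM. Compound 4 may still come back as a limit rather than a number.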

Compound 4, half-maximal inhibitory concentration: > 50000 nM
Compound 4: a limit, no number (the forecaster's own chance of this, stated with the estimate: 40%); middle value at least 1.6-fold (0.22 log units) from the limit.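

In this assay compound 4 gives > 50000 nM, which is a limit of the assay and not a number. Compound 3 sits at the same limit, so no step can be read from one to the other because neither has a number: the limit of > 50000 nM in this assay, at which 3 of the 4 values shown sit.

The compounds shown leave open whether trading phenyl for methoxycarbonyl changes the number on the core of compound 3 as it does on the core of compound 1.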